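A few compounds are considered here, and "the series" means these few. Any claim that something is new, unique, unknown or untested is made for them only; others in the source may bear on it.

Working notes on the butylamino-to-allylamino step.

Compound 1 `CCCCNc1nnc(SCC(=O)N(Cc2cccc([N+](=O)[O-])c2)c2ccc(F)cc2)s1` is the reference. In an assay on isolated protein for inhibition of Amine oxidase [flavin-containing] A (Homo sapiens), read by fluorescence and Amplex Red, with a stated time of 30 min, tested at 1 mM (on this read-out higher numbers stand for a stronger effect at the one concentration tested and lower numbers for a weaker effect), compound 1 gives 90.5%. Two neighbours carry the same core with a shorter or branched chain on the ring nitrogen: compound 2 `CCCNc1nnc(SCC(=O)N(Cc2cccc([N+](=O)[O-])c2)c2ccc(F)cc2)s1` gives 95% and compound 3 `CC(C)CNc1nnc(SCC(=O)N(Cc2cccc([N+](=O)[O-])c2)c2ccc(F)cc2)s1` gives 93.5%. Among these three numbers compound 1 holds the lowest, but every gap is inside the scatter: a number 4.5 percentage points higher from compound 1 to compound 2 (within the scatter), a number 3 percentage points higher from compound 1 to compound 3 (within the scatter), and between the two neighbours a number 1.5 percentage points lower from compound 2 to compound 3 (within the scatter).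

Compound 4 `C=CCNc1nnc(SCC(=O)N(Cc2cccc([N+](=O)[O-])c2)c2ccc(F)cc2)s1` is not yet measured. Against compound 1 the change is vinyl in place of propyl on a saturated chain carbon bound to a nitrogen on an aromatic ring. For the measured compounds named here, the steps that bear on it are those that also alter the saturated chain on the ring nitrogen, hydrogen for methyl and isopropyl for propyl, and both stayed within the scatter, so the read-out looks insensitive to the shape of this chain over the range covered. Going by the values given here, the new change removes one carbon from the chain and introduces a double bond outside aromatic rings, which none of the measured pairs has probed; still, with every known chain variation flat, the expected step in this assay from compound 1 to compound 4 is none beyond the scatter, a number 1.5 percentage points higher from compound 1 to compound 4 (within the scatter). Compound 4 is therefore estimated at 92%, with a range from 84% to 97%.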

Compound 4, a percentage reported as inhibition, at one concentration (the size of the read-out at that concentration, not a potency): 92%
Beside the measured number, compound 4's estimate shows no gap at the digits printed; the range from low to high includes it.
By their numbers in this assay, from the lowest: compounds 1, 4, 3 and 2 (each within the scatter of the next).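

The double bond outside aromatic rings is new at this place, on a saturated chain carbon bound to a nitrogen on an aromatic ring, and in this assay it leaves no step beyond the scatter against any of the three saturated chains: a number 1.5 percentage points higher from compound 1 to compound 4 (within the scatter), a number 1.5 percentage points lower from compound 3 to compound 4 (within the scatter) and a number 3 percentage points lower from compound 2 to compound 4 (within the scatter). The flat picture thus extends from chain length and branching to unsaturation, and compounds 1, 2, 3 and 4 cannot be told apart by this read-out, with no exception among them. Nothing available explains this insensitivity at the chain on the ring nitrogen.

As far as these compounds go, whether a carboxylic acid or a free amine at the end of this chain, a longer chain, or a phenyl ring in place of the chain would produce a step beyond the scatter remains open. The read-out also gives the size of the effect at one concentration and not a potency, so any differences in potency among these four compounds remain unresolved.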